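From propyl to butyl: compound 2 to compound 4

This account rests on a few compounds, and the source may have more. Where it says the series, first, only, none or still open, it means among the compounds named here.

In an ADME assay on J774.1 cells (Mus musculus) for cytotoxicity, read by resazurin assay, with a stated time of 48 h (a lower number here means a stronger inhibitor, a higher number a weaker inhibitor), compound 1 `CCCn1cc(C(=O)NCc2ccccc2)c(=O)c2cc(F)c(N3CCC(C(N)=O)CC3)cc21` gives 43700 nM. Compound 2 `CCCn1cc(C(=O)NCc2ccco2)c(=O)c2cc(F)c(N3CCC(C(N)=O)CC3)cc21` gives 56900 nM, which lies within the scatter of compound 1, its nearest number. Compound 3 `CCCn1cc(C(=O)O)c(=O)c2cc(F)c(Cl)cc21` returns only a limit, > 100000 nM. Any reading of this small set has to allow for (the limit of > 100000 nM in this assay, at which 1 of the 3 values shown sits).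

Compound 4 `CCCCn1cc(C(=O)NCc2ccco2)c(=O)c2cc(F)c(N3CCC(C(N)=O)CC3)cc21` differs from compound 2 by methyl in place of hydrogen on a saturated chain carbon, three bonds along the chain from an aromatic nitrogen. The change is methyl in place of hydrogen on a saturated chain carbon, three bonds along the chain from an aromatic nitrogen, so that propyl becomes butyl.

For the measured compounds named here, no measured step alters this chain, so the data offer no direct guide to the change. Going by the values given here, the one measured step that reaches compound 2 sits elsewhere, with furan-2-yl in place of phenyl, and it is small: a 1.3-fold higher number from compound 1 to compound 2 (0.11 log units; within the scatter). It offers only weak support, but on that basis a step beyond the scatter is not expected in this assay, and no direction is firmly expected either. The expected change is estimated as a 1.1-fold lower number from compound 2 to compound 4 (0.06 log units; within the scatter). For compound 4 the expected value is 50000 nM, with an estimated range of 25000 nM to 95000 nM.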

Compound 4, half-maximal inhibitory concentration: 41400 nM
Beside the measured number, compound 4's estimate is 1.2-fold (0.08 log units) above it; low and high end bracket the measured number.
By their numbers in this assay, from the lowest: compounds 4, 1 and 2 (each within the scatter of the next). At a limit, above all of these: compound 3.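

For the compounds shown here, the earlier compounds all carry propyl, so this is the first measured change to the chain on the aromatic nitrogen. With methyl in place of hydrogen on a saturated chain carbon, three bonds along the chain from an aromatic nitrogen, this assay gives a 1.4-fold lower number from compound 2 to compound 4 (0.14 log units; within the scatter) as the whole effect of going from propyl to butyl. On this one pair, then, the chain can take that change without a step beyond the scatter, though the pair carries furan-2-yl on the amide side and says nothing of how the same change reads with phenyl there.

On these data alone, whether a longer chain such as hexyl, a branched chain such as isopropyl, or a chain ending in an amine would also stay within the scatter of compound 2 remains open. Compound 3 stands only at a limit, and any wider reading of the set has to allow for it: the limit of > 100000 nM in this assay, at which 1 of the 4 values shown sits.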